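The source may hold more compounds than are shown below. What is called first, only, known or untested is meant among the compounds shown, and "the series" means these compounds.

Measured so far in an assay (strain Wistar) for displacement of a labelled ligand from adenosine receptor A1 (Rattus norvegicus), read by scintillation counting; a lower number here means a stronger inhibitor, a higher number a weaker inhibitor:
Compound 1 `CCOc1ccccc1C(=O)Nc1nc(-c2ccccc2)nc2c1nnn2Cc1ccccc1` gives 1850 nM
Compound 2 `COc1ccccc1C(=O)Nc1nc(-c2ccccc2)nc2c1nnn2Cc1ccccc1` gives 1520 nM

Among the compounds with values here, compound 1 has the highest of the two numbers in this assay; the only neighbour, compound 2, gives a number that is a 1.2-fold lower number from compound 1 to compound 2 (0.09 log units; within the scatter), which is within the scatter. Compound 3 `O=C(Nc1nc(-c2ccccc2)nc2c1nnn2Cc1ccccc1)c1ccc(Cl)cc1` is the next compound to be measured. It differs from compound 1 in one place: 4-chlorophenyl in place of 2-ethoxyphenyl on a carbonyl carbon. The shared core and its amide link stay untouched, and only the ring attached to the carbonyl carbon changes. Within the data shown here, the single measured step, from compound 1 to compound 2, concerns a different change, the shortening of the ethoxy group, and says nothing about exchanging the whole ring. Among the measured compounds shown here, no measured step therefore bears on this change, and there is no ground to expect a shift beyond the scatter in either direction. The step from compound 1 to compound 3 in this assay is accordingly expected to be a 1.2-fold lower number from compound 1 to compound 3 (0.06 log units; within the scatter). For compound 3 the estimate is 1600 nM, in a range from 500 nM to 5000 nM.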

Compound 3, inhibition constant: 108 nM
Compound 3: middle estimate off by 15-fold (1.17 log units), on the high side; the measured number lies below the stated range.
By their numbers in this assay, from the lowest: compound 3; then compounds 2 and 1 (each within the scatter of the next).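

In this assay, the ring on the carbonyl carbon matters far more than the length of the alkoxy chain on it: 4-chlorophenyl in place of 2-ethoxyphenyl gives a 17-fold lower number from compound 1 to compound 3 (1.23 log units; beyond the scatter), and 4-chlorophenyl in place of 2-methoxyphenyl gives a 14-fold lower number from compound 2 to compound 3 (1.15 log units; beyond the scatter). The earlier step between the two alkoxy compounds stayed within the scatter, so only the exchange of the whole ring has so far moved the number at this position. Nothing available explains why this exchange produces so large a step.

The exchange alters both the group on the ring and where it sits, so the compounds shown cannot separate the arrival of the chlorine from the departure of the alkoxy group. As far as these compounds go, how a plain phenyl ring, or a bromine in place of the chlorine, would compare remains open.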